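The source may report more compounds than this note shows. Statements on the series, on what has been measured and on what is new or still open speak of the compounds shown alone.

Compound 1, `Cc1nc2c3ccccc3ccc2c2nc3c(ccc4ccccc43)c(-c3nccnc3N)c12`: 47.8 ug/mL
Compound 2, `Cc1nc2c3ccccc3ccc2c2nc3c(ccc4ccccc43)c(-c3cc([N+](=O)[O-])ccc3N)c12`: 43.3 ug/mL
Compound 3, `Cc1nc2c3ccccc3ccc2c2nc3c(ccc4ccccc43)c(-c3ccccc3Cl)c12`: 74.6 ug/mL

In a functional assay, read by spectrophotometry, with a stated time of 15 min (on this read-out higher numbers stand for weaker inhibition and lower numbers for stronger inhibition), compound 2 gives the lowest number of the three, yet the step of a 1.1-fold lower number from compound 1 to compound 2 (0.04 log units; within the scatter) and the step of a 1.7-fold higher number from compound 2 to compound 3 (0.24 log units; within the scatter) both lie within the scatter, so the three compounds are not separated on this read-out. Compound 4, `Cc1nc2c3ccccc3ccc2c2nc3c(ccc4ccccc43)c(-c3cc(O)nc4ccccc34)c12`, differs from compound 2 in one place: 2-hydroxyquinolin-4-yl in place of 2-amino-5-nitrophenyl on an aromatic carbon. The two measured changes at that same aromatic carbon, the 3-aminopyrazin-2-yl and the 2-chlorophenyl group, each left the number within the scatter of compound 2, and there is no measured change to a 2-hydroxyquinolin-4-yl group. The step of a 1.2-fold higher number from compound 2 to compound 4 (0.06 log units; within the scatter) is therefore expected to be none beyond the scatter. Compound 4 is estimated at 50 ug/mL in this assay, with a range from 22 ug/mL to 110 ug/mL.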

Compound 4, half-maximal inhibitory concentration: 44.8 ug/mL
Estimate against measurement, compound 4: 1.1-fold (0.05 log units) above, within the range that was stated.
By their numbers in this assay, from the lowest: compounds 2, 4, 1 and 3 (each within the scatter of the next).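

In this assay the 2-hydroxyquinolin-4-yl group, the only group shown with two aromatic rings on this aromatic carbon opposite the ring nitrogen, stays unseparated from the single-ring groups in all three comparisons (a 1.0-fold higher number from compound 2 to compound 4 (0.01 log units; within the scatter)), (a 1.1-fold lower number from compound 1 to compound 4 (0.03 log units; within the scatter)) and (a 1.7-fold lower number from compound 3 to compound 4 (0.22 log units; within the scatter)). Across these four compounds, then, the larger group moves the number no further than the scatter. Nothing measured here bears on why the number stays so flat.

As far as these compounds go, whether a group with no aromatic ring at this carbon, such as a simple amine or a carboxylic acid, would move the number beyond the scatter remains open. So does the effect of any change elsewhere on the shared core.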